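The source may report more compounds than this note shows. Statements on the series, on what has been measured and on what is new or still open speak of the compounds shown alone.

- Compound 1 `COc1cc(N2CCN(C(=O)N3CCC(O)C3)CC2)ccc1Nc1nc(NC2CCCCC2)c2nc[nH]c2n1` gives 47% as its value
- Compound 2 `COc1cc(N2CCN(CC3CCOC3)CC2)ccc1Nc1nc(NC2CCCCC2)c2nc[nH]c2n1` gives 59% as its value
- Compound 3 `COc1cc(N2CCC(C(=O)N3CCC(N(C)C)C3)CC2)ccc1Nc1nc(NC2CCCCC2)c2nc[nH]c2n1` gives 60% as its value

These values all come from an ADME assay on microsomes from liver (Mus musculus) for metabolic stability, read by mass spectrometry, with a stated time of 40 min, tested at 1 uM (a lower number here means that less of the compound is left, a higher number that more of the compound is left), and no other read-out is at hand. Compound 3 lies within the scatter of compound 2 and beyond the scatter over compound 1. The next case is compound 4 `COc1cc(N2CCC(CC(=O)N3CCCC3)CC2)ccc1Nc1nc(NC2CCCCC2)c2nc[nH]c2n1` and its difference from compound 3 is a single change (((pyrrolidin-1-yl)carbonyl)methyl in place of (3-(dimethylamino)pyrrolidin-1-yl)carbonyl on a saturated ring carbon), with ((pyrrolidin-1-yl)carbonyl)methyl in place of (3-(dimethylamino)pyrrolidin-1-yl)carbonyl on a saturated ring carbon. Going by the values given here, only one measured step is available, a number 12 percentage points higher from compound 1 to compound 2 (beyond the scatter) and modest in size, and it swaps different groups on an amine nitrogen in a ring, so it bears on this change only loosely. Among the compounds with values here, no measured pair covers this exact swap. In this assay, on these data alone, no step beyond the scatter is therefore expected, and the direction stays open. The estimated step is a number 5 percentage points lower from compound 3 to compound 4 (within the scatter) and it is expected to remain within the scatter. For compound 4 the expected value is 55% with an estimated range from 38% to 71% in this assay.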

Compound 4, percent of the compound remaining: 59%
Estimate against measurement, compound 4: 4 percentage points below, and the stated range covers the measured number.
By their numbers in this assay, from the lowest: compound 1; then compounds 2, 4 and 3 (each within the scatter of the next).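

In this assay, ((pyrrolidin-1-yl)carbonyl)methyl in place of (3-(dimethylamino)pyrrolidin-1-yl)carbonyl on a saturated ring carbon gives a number 1 percentage points lower from compound 3 to compound 4 (within the scatter). Going by these compounds alone, this is the first measured step at this place, since the earlier one concerned an amine nitrogen in a ring. Even with the dimethylamino part gone and the carbonyl carried on a methyl, the read-out stays within the scatter, so this swap shows no measurable effect on the percent of compound remaining. Nothing at hand explains this result.

The compounds shown leave open whether a carboxylic acid or a longer chain on this saturated ring carbon would also stay within the scatter of compound 4. They also leave open whether a primary amine there would give a step beyond it.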